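Nonyl thioether in place of the hydroxyphenyl anilide

The compounds below may be only part of what the source reports. "The series", "measured", "known", "first", "only" and "open" are said of these compounds alone.

Of the compounds shown here, three built on one shared core have been tested in an assay on isolated protein (Mus musculus) for inhibition of IL15-IL15 receptor (Homo sapiens), read by resazurin assay, with stated times of 30 min and 2.5 days; on this read-out higher numbers stand for weaker inhibition and lower numbers for stronger inhibition. Compound 1 `CC(C)Oc1ccc(NC(=O)CSc2nnc(Cc3nn(C)c(=O)c4ccccc34)n2C)cc1` is reported in this assay only at a limit of the assay, > 30000 nM. That limit is the limit of > 30000 nM in this assay, at which 1 of the 3 values shown sits. Among the compounds with values here, compound 2 `Cn1c(Cc2nn(C)c(=O)c3ccccc23)nnc1SCCCCCCCCCCC(=O)Oc1ccc(Cl)cc1Cl` gives 8700 nM in this assay, the only plain number among the three. Compound 3 `Cn1c(Cc2nn(C)c(=O)c3ccccc23)nnc1SCC(=O)Nc1ccc(O)cc1` is recorded in this assay as "not active" (no number reported), with no number attached, so it stands among the weakest entries shown, without a figure to compare against compound 2.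

The change to compound 4 `CCCCCCCCCCSc1nnc(Cc2nn(C)c(=O)c3ccccc23)n1C` is nonyl in place of (4-hydroxyphenyl)carbamoyl on a saturated chain carbon bound to a sulfur. Within the data shown here, no measured pair differs in a single place, so the size of this step can only be guessed. Among the measured compounds shown here, the one compound with a long chain on the sulfur, compound 2, gives 8700 nM. On that basis compound 4 is expected to remain weak in this assay, with an estimated value of 20000 nM, ranging from 5000 nM to 60000 nM, and a real chance that only a limit is reported.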

Compound 4, half-maximal inhibitory concentration: 7600 nM
For compound 4 the middle estimate is 2.6-fold (0.42 log units) above the measured one; the range from low to high includes it.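

Compound 3 stands in this assay as "not active" (no number reported) with (4-hydroxyphenyl)carbamoyl on a saturated chain carbon bound to a sulfur, while compound 4 gives 7600 nM with nonyl there, so this position takes a plain carbon chain and still returns a number, although the step between the two cannot be read. Hydrogen in place of the (2,4-dichlorophenoxy)carbonyl at the far end of the long chain gives a 1.1-fold lower number from compound 2 to compound 4 (0.06 log units; within the scatter) and so that group is not needed for this reading. Nothing given here bears on what lies behind either result.

On these data alone, whether a shorter or a longer chain on the sulfur would change the reading stays open. So does the effect of an amine or a carboxylic acid at the end of the chain.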